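The source may hold more compounds than are shown below. What is called first, only, known or untested is meant among the compounds shown, and "the series" means these compounds.

Measured so far:
- compound 1, `O=c1n([C@H]2CO[C@H](CO)O2)cc(F)c2nc(CO)cn12`: 1390000 nM
- compound 2, `O=c1n([C@H]2CO[C@@H](CO)O2)ccc2nc(-c3ccc([N+](=O)[O-])cc3)cn12`: 486000 nM
- compound 3, `O=c1n(C2COC(CO)O2)ccc2nc(CO)cn12`: 618000 nM

All three numbers come from an ADME assay on HepG2 2.2.15 cells (Homo sapiens) for cytotoxicity, read by neutral red uptake; a higher number here means that more compound is tolerated, a lower number that less compound is tolerated. Compound 1 stands highest of the three. Its nearest neighbour is compound 3, whose number in this assay is lower by a margin beyond the scatter, and the furthest is compound 2, lower again by a wider margin that is also beyond the scatter. Within this small set compound 1 is therefore the best-tolerated compound. For the measured compounds named here, no pair among the three differs in a single place, so no single structural step can be read off from the measured numbers.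

The next compound is compound 4, `O=c1n([C@H]2CO[C@@H](CO)O2)cc(F)c2nc(CO)cn12`. It differs from compound 1 as follows: the two compounds have the same atoms and bonds and differ only in configuration as drawn: 1 of 2 stereo elements differ; a stereocentre at a saturated ring carbon is drawn S in compound 1 and R in compound 4.

Going by the values given here, with no measured stereochemical pair, there is nothing to calibrate this kind of change against. A change in configuration alone at a saturated ring carbon, with every atom and bond retained, is expected to move the number in this assay little, if at all; the step from compound 1 to compound 4 is expected to be a 1.3-fold lower number from compound 1 to compound 4 (0.10 log units; within the scatter), that is, within the scatter, with no preferred direction. For compound 4 the estimate in this assay is 1100000 nM, with a range from 450000 nM to 2600000 nM.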

Compound 4, half-maximal cytotoxic concentration: 1060000 nM
Compound 4: the middle estimate sits 1.0-fold (0.02 log units) above what was measured, within the range that was stated.
By their numbers in this assay, from the lowest: compounds 2, 3, 4 and 1 (each within the scatter of the next, the first and the last beyond it).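

In this assay the series now has its first pair differing in one place, and the step is a 1.3-fold lower number from compound 1 to compound 4 (0.12 log units; within the scatter), which lies within the scatter. At this saturated ring carbon, then, the drawn S and R forms cannot be told apart by this read-out, at least on the core shared by this pair, and the tolerated concentration gives no ground for preferring one configuration. The reading is a direct one, with no second structural difference to separate from it: the fact that compounds 1 and 4 differ only in the configuration as drawn

The pair covers one of the two stereo elements on one core, so the compounds shown leave open whether the other stereo element is equally silent, and whether the same holds on a core carrying the 4-nitrophenyl group of compound 2 or lacking the fluorine of compound 1. Also open, from the compounds shown here alone, is how the number would respond to an amine or a carboxylic acid in place of the hydroxymethyl group, and whether configuration at this carbon would then begin to separate the two forms.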